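Swapping fluorine for methyl on a urea aryl group

The source may hold more compounds than are shown below. What is called first, only, known or untested is meant among the compounds shown, and "the series" means these compounds.

Of the compounds shown here, two sharing the same core have been measured. Compound 1 `CSc1cc(C)nc(SC)c1NC(=O)N(Cc1ccccc1)Cc1cccc(-c2cc[nH]n2)c1` gives 99 nM in an assay on small intestine for displacement of a labelled ligand from acyl-CoA:cholesterol acyltransferase (Oryctolagus cuniculus); a higher number here means a weaker inhibitor, a lower number a stronger inhibitor. Compound 2 `O=C(Nc1c(F)cc(F)cc1F)N(Cc1ccccc1)Cc1cccc(-c2cc[nH]n2)c1` gives 14 nM in the same assay, and the change between them, a 7.1-fold lower number from compound 1 to compound 2 (0.85 log units; beyond the scatter), shows that the aryl group on the amide-type nitrogen has a clear effect on the number. For the measured compounds named here, compound 2 therefore stands at the lower of the two values so far.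

Going by the values given here, compound 3 `Cc1cc(C)c(NC(=O)N(Cc2ccccc2)Cc2cccc(-c3cc[nH]n3)c2)c(C)c1` keeps everything else and changes only that aryl group: 2,4,6-trimethylphenyl in place of 2,4,6-trifluorophenyl on an amide-type nitrogen. Among the compounds with values here, the single measured step bears on it only indirectly, since it exchanged a heteroaromatic ring with two thioether substituents for a carbon-only ring, whereas here one carbon-only ring with three small substituents replaces another of the same pattern. Nothing in the measured pair tells whether methyl or fluorine serves better at these three positions, so a small step in either direction, not clearly beyond the scatter, is the reasonable expectation.

Compound 3 is estimated at 20 nM, within a range from 6 nM to 70 nM, which means an expected step of a 1.4-fold higher number from compound 2 to compound 3 (0.15 log units; within the scatter).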

Compound 3, half-maximal inhibitory concentration: 21 nM
Compound 3: middle estimate off by 1.1-fold (0.02 log units), on the low side; low and high end bracket the measured number.
By their numbers in this assay, from the lowest: compounds 2 and 3 (each within the scatter of the next); then compound 1.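

In this assay, exchanging 2,4,6-trifluorophenyl for 2,4,6-trimethylphenyl on the amide-type nitrogen gives a 1.5-fold higher number from compound 2 to compound 3 (0.18 log units; within the scatter), so this assay does not separate the two groups, even though fluorine and methyl are quite different substituents. The step from the sulfur-bearing heteroaromatic group to the trimethylphenyl group, a 4.7-fold lower number from compound 1 to compound 3 (0.67 log units; beyond the scatter), lies beyond the scatter, which shows that the lower number seen earlier with the trifluorophenyl group does not require fluorine, at least among these three compounds. Nothing available here accounts for why the two groups give numbers within the scatter of each other.

The compounds shown leave open whether the three substituents matter at all, since both carbon-only aryl groups carry the same pattern, and a plain phenyl group would speak to that question. Going by these compounds, it also remains open how the number would respond to other substituents in that pattern, such as chlorine or methoxy, or to a hydroxyl or an amine, which would bring in groups unlike either fluorine or methyl.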